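Ester to amide on the shared core: lipophilicity outlook

The source may hold more compounds than are shown below. What is called first, only, known or untested is meant among the compounds shown, and "the series" means these compounds.

Measured compounds:
compound 1, `C#CCCOC(=O)/C=C(C)/C=C/CC(C)CCCC(C)(C)OC`, 5.2;
compound 2, `C/C=C/COC(=O)/C=C(C)/C=C/CC(C)CCCC(C)(C)OC`, 6.07;
compound 3, `CCOC(=O)/C=C(C)/C=C/CC(C)CCCC(C)(C)OCC`, 6.08.

In a physicochemical assay for lipophilicity (a higher number here means a more lipophilic compound, a lower number a more polar compound), compound 2 stands second highest of the three numbers. For the measured compounds named here, compound 3 lies within the scatter of it, so no order between these two can be claimed, while compound 1 sits well below it: the change a number 0.87 log units higher from compound 1 to compound 2 (beyond the scatter) is the only step here that is beyond the scatter.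

Compound 4, `COC(C)(C)CCCC(C)C/C=C/C(C)=C/C(=O)NC(C)C`, has not been measured. It differs from compound 2 by isopropylamino in place of (but-2-en-1-yl)oxy on a carbonyl carbon. Going by the values given here, this is a change at the carbonyl carbon, whereas the one measured step concerns a saturated chain carbon bound to an oxygen; no measured pair covers a swap of an oxygen for a nitrogen, and compound 4 brings in a hydrogen-bond donor that none of the measured compounds carries. The step therefore cannot be read off directly, and the expectation is a clear drop in this assay rather than no change.

For compound 4 the estimate is 4.5, within 3.8 to 5.3. The expected step of a number 1.57 log units lower from compound 2 to compound 4 (beyond the scatter) is thus downward and beyond the scatter.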

Compound 4, partition coefficient: 4.45
Compound 4: middle estimate off by 0.05 log units, on the high side, and the stated range covers the measured number.
By their numbers in this assay, from the lowest: compound 4; then compound 1; then compounds 2 and 3 (each within the scatter of the next).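

In this assay, for the compounds shown here, the carbonyl carbon proves to be a sensitive position: isopropylamino in place of (but-2-en-1-yl)oxy gives a number 1.62 log units lower from compound 2 to compound 4 (beyond the scatter), the first measured change at this carbonyl carbon. The same swap starting from (but-3-yn-1-yl)oxy gives a number 0.75 log units lower from compound 1 to compound 4 (beyond the scatter), so the downward direction holds for both esters that differ from the amide in this one place, although the size of the step depends on which ester group leaves. Nothing available explains why the number moves in this way at this position.

Only one amide is shown, so how much of the step goes with the amide hydrogen and how much with the isopropyl group remains open. A dimethylamino or butylamino group on the same carbonyl carbon would help to separate the two.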